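The compounds below may be only part of what the source reports. "The series", "measured", "known", "first", "only" and "open" are said of these compounds alone.

Measured compounds:
compound 1, `O=C1NC(=S)/C(=C/c2ccccc2Cl)S1`: 5.97%
compound 2, `O=C1NC(=S)/C(=C/c2ccccc2F)S1`: 8.86%
compound 3, `O=C1NC(=S)/C(=C/c2ccc(Cl)cc2Cl)S1`: 20%

In a functional assay on HEp-2 cells (Homo sapiens) for cytotoxicity, read by MTT assay, with a stated time of 72 h, tested at 5 ug/mL (a lower number here means less inhibition of growth, a higher number more inhibition of growth at the concentration tested), compound 1 gives 5.97%, the lowest of the three numbers shown. Its nearest neighbour is compound 2, with a number 2.9 percentage points higher from compound 1 to compound 2 (within the scatter); furthest is compound 3, with a number 14 percentage points higher from compound 1 to compound 3 (beyond the scatter).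

The unmeasured compound 4, `O=C1NC(=S)/C(=C/c2c(Cl)cccc2Cl)S1`, is reached from compound 1 by the following change: chloro in place of hydrogen on an aromatic carbon The second chloro enters meta to the chloro group already present in compound 1.

For the measured compounds named here, of the measured steps, only the one from compound 1 to compound 3 matches in kind, since a chloro also enters in place of hydrogen there, though at another aromatic carbon. That step was a number 14 percentage points higher from compound 1 to compound 3 (beyond the scatter), a modest rise beyond the scatter. The step from compound 1 to compound 2, a halogen exchange, lay within the scatter and bears little on the present change. A rise of similar, modest size in this assay is therefore expected, though the place differs and a smaller change cannot be excluded.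

Compound 4 is expected to give about 16%, within a range from 4% to 30%. The estimated step is a number 10 percentage points higher from compound 1 to compound 4 (within the scatter).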

Compound 4, percent growth inhibition at one concentration: -2.39%
Estimate against measurement, compound 4: 18.4 percentage points above, outside the stated range (below it).
By their numbers in this assay, from the lowest: compounds 4, 1 and 2 (each within the scatter of the next, the first and the last beyond it); then compound 3.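

At this place, ortho to a group of 8 heavy atoms and meta to a chloro group, a chloro in place of hydrogen did not bring the rise seen at another aromatic carbon. In this assay, the step of a number 14 percentage points higher from compound 1 to compound 3 (beyond the scatter) had pointed to a gain from a second chloro, but the step of a number 8.4 percentage points lower from compound 1 to compound 4 (within the scatter) shows that the same kind of change does not give that gain at every place on this ring, so its result depends on where the chloro enters. No measurement shown bears on why the two places differ.

The compounds shown leave open whether a methoxy group or an amine at this same place would give a step beyond the scatter. They also leave open whether a fluoro there would behave as the chloro does.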